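The compounds below may be only part of what the source reports. "The series", "measured", "known", "first", "only" and "open" are said of these compounds alone.

The series is built on compounds 1, 2 and 3, and the only read-out is a functional assay on NCI-H460 cells (Homo sapiens) for cytotoxicity, read by MTT assay; a lower number here means a stronger inhibitor, a higher number a weaker inhibitor. Compound 1 has the structure `Cc1nc(Nc2ccccc2)sc1C(=O)/C=C/c1ccc(Cl)cc1`. In this assay compound 1 reaches only a limit, given as > 25000 nM. Compound 2, with the structure `Cc1ccccc1Nc1nc(C)c(C(=O)/C=C/c2ccc(Cl)cc2)s1`, differs from compound 1 by the change (methyl in place of hydrogen on an aromatic carbon). For compound 2 this assay again reports only a limit, > 25000 nM. The resulting step is a step that the two limits leave unreadable from compound 1 to compound 2, and this rests on (the limit of > 25000 nM in this assay, at which 3 of the 3 values shown sit).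

Compound 3 has the structure `COc1cc(/C=C/C(=O)c2sc(Nc3ccccc3)nc2C)cc(OC)c1OC`. How its core differs from that of compound 1 is not broken down here. In this assay compound 3 also gives only a limit, namely > 25000 nM.

Compound 4, with the structure `COc1cc(/C=C/C(=O)c2sc(Nc3ccc(C)cc3)nc2C)cc(OC)c1OC`, has not yet been measured. It differs from compound 3 by methyl in place of hydrogen on an aromatic carbon. This is the same kind of change as that from compound 1 to compound 2, but not the same: there the methyl sits ortho to a large group, here it sits para to a large group.

Since compound 3 shows only a limit at > 25000 nM and the earlier step that the two limits leave unreadable from compound 1 to compound 2 was left unreadable by two limits, the step from compound 3 to compound 4 is estimated at a step that the limit leaves unreadable from compound 3 to compound 4. Compound 4 is therefore expected to show about 40000 nM in this assay, most likely again as a limit.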

Compound 4, half-maximal inhibitory concentration: > 25000 nM
Compound 4: only a limit was reported; the forecaster's own chance of this, stated with the estimate: 85%; the middle value is on the limit's open side.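

In this assay compound 4 also gives only a limit, > 25000 nM. Compound 3 is likewise reported only as a limit, so no step can be read between compound 3 and compound 4: the limit of > 25000 nM in this assay, at which 4 of the 4 values shown sit.

The compounds shown leave open whether any member of this series reaches a measurable value in this assay, and whether methyl in place of hydrogen on an aromatic carbon changes that value at all.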